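Halogen exchange on the fused benzo ring: compound 3

The compounds below may be only part of what the source reports. "The series", "measured", "known", "first", "only" and "open" are said of these compounds alone.

Measured so far in a functional assay on K562 cells (Homo sapiens) for antiproliferative activity, read by MTT assay, with a stated time of 48 h; a higher number here means a weaker inhibitor, a lower number a stronger inhibitor:
- compound 1, `COc1ccc2c(c1)C1(C(=O)N2Cc2ccccc2)C(C#N)=C(N)Oc2cc3oc(-c4ccccc4)cc(=O)c3c(O)c21`: a limit only, > 50000 nM
- compound 2, `N#CC1=C(N)Oc2cc3oc(-c4ccccc4)cc(=O)c3c(O)c2C12C(=O)N(Cc1ccccc1)c1ccc(F)cc12`: a limit only, > 50000 nM

Compound 1 reaches no number in this assay; its value is a limit of the assay. Compound 2 likewise returns only a limit in this assay. Both values sit at the limit of > 50000 nM in this assay, at which 2 of the 2 values shown sit. Among the measured compounds shown here, the single measured step, a step that the two limits leave unreadable from compound 1 to compound 2, is therefore not readable in either direction, and compound 2 cannot be placed relative to compound 1 beyond the statement that both lie at the limit.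

Compound 3 `N#CC1=C(N)Oc2cc3oc(-c4ccccc4)cc(=O)c3c(O)c2C12C(=O)N(Cc1ccccc1)c1ccc(Br)cc12` is the next member. It differs from compound 2 by bromo in place of fluoro on an aromatic carbon. For the measured compounds named here, the only measured step that bears on this change is the one from compound 1 to compound 2, and that step is unreadable, so nothing shows that such an exchange moves the read-out beyond the usual scatter. Two analogues already sit at the limit, and compound 3 is expected to remain there as well. The estimate for compound 3 is 60000 nM, with a range of 20000 nM to 200000 nM. This corresponds to an expected step that the limit leaves unreadable from compound 2 to compound 3, which is no change beyond scatter.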

Compound 3, half-maximal inhibitory concentration: 36400 nM
The estimate for compound 3 lay 1.6-fold (0.22 log units) above the measured number; the range from low to high includes it.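

Working notes on the halogen position: in this assay compound 3 gives 36400 nM, the only number among the three compounds shown, so a member with this substitution on the six-membered aromatic ring of carbon only can be read within the range of the assay. Bromo in place of fluoro gives an at least 1.3-fold lower number from compound 2 to compound 3 (0.13 log units; that floor lies within the scatter), and bromo in place of methoxy gives an at least 1.3-fold lower number from compound 1 to compound 3 (0.13 log units; that floor lies within the scatter). Compound 1 and compound 2 remain limits rather than numbers, so both steps are floors only, and neither floor shows a change beyond the scatter: the limit of > 50000 nM in this assay, at which 2 of the 3 values shown sit.

From the compounds shown here alone, the true distance between compound 3 and either neighbour stays open, and so does the question of whether bromo differs from fluoro or methoxy at this place by more than the scatter. Also open, going by these compounds, is how chloro, iodo, an amine or a carboxylic acid on the same aromatic carbon would read in this assay, and whether any such group would bring the series to numbers well clear of the limit.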